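Alkyne arm: hydroxypyrrolidine in place of the sulfonamide

The compounds below may be only part of what the source reports. "The series", "measured", "known", "first", "only" and "open" are said of these compounds alone.

Three measured compounds share one core and differ only in the group on the triple-bonded carbon. Compound 1 `COc1cc[nH]c1/C=C1\C(=O)Nc2ccc(F)c(C#C[C@@H](C)O)c21` gives 130 nM in a functional assay on SW480 cells (Homo sapiens) for inhibition (on this read-out lower numbers stand for stronger inhibition and higher numbers for weaker inhibition), and compound 2 `COc1cc[nH]c1/C=C1\C(=O)Nc2ccc(F)c(C#C[C@H](C)O)c21` gives 400 nM; the step of a 3.1-fold higher number from compound 1 to compound 2 (0.49 log units; beyond the scatter) rests on (the fact that compounds 1 and 2 differ only in the configuration as drawn). Compound 3 `COc1cc[nH]c1/C=C1\C(=O)Nc2ccc(F)c(C#C[C@@H](NS(C)(=O)=O)[C@@H](C)O)c21` gives 1190 nM and stands weakest of the three, since the steps of a 9.2-fold higher number from compound 1 to compound 3 (0.96 log units; beyond the scatter) and a 3.0-fold higher number from compound 2 to compound 3 (0.47 log units; beyond the scatter) both lie beyond the scatter. Compound 4 `COc1cc[nH]c1/C=C1\C(=O)Nc2ccc(F)c(C#C[C@@H]3C[C@@H](O)CN3)c21` is not yet measured; it differs from compound 3 by 4-hydroxypyrrolidin-2-yl in place of 2-hydroxy-1-(methanesulfonamido)propyl on a triple-bonded carbon. The two steps that bear on this change, from compound 1 to compound 3 and from compound 2 to compound 3, show that the larger open-chain group on that carbon went with a higher number; compound 4 returns to a ring-bound group of fewer heavy atoms that again carries a hydroxyl, so a lower number is expected, of a size between those two steps. The estimate for compound 4 in this assay is 300 nM, within 90 nM to 1000 nM, which means an expected step of a 4.0-fold lower number from compound 3 to compound 4 (0.60 log units; beyond the scatter).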

Compound 4, half-maximal inhibitory concentration: 44 nM
The estimate for compound 4 lay 6.8-fold (0.83 log units) above the measured number, and the stated range ends above it.
By their numbers in this assay, from the lowest: compound 4; then compound 1; then compound 2; then compound 3.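

In this assay, the group on the triple-bonded carbon can lower the number as well as raise it, and 1-hydroxyethyl does not mark the best result seen at this position: there is a 3.0-fold lower number from compound 1 to compound 4 (0.47 log units; beyond the scatter), and also a 9.1-fold lower number from compound 2 to compound 4 (0.96 log units; beyond the scatter). Compound 4 is therefore the strongest of the four, with all of its steps beyond the scatter. The exchange of 2-hydroxy-1-(methanesulfonamido)propyl for 4-hydroxypyrrolidin-2-yl produces the largest step in the set, a 27-fold lower number from compound 3 to compound 4 (1.43 log units; beyond the scatter).

Which part of 4-hydroxypyrrolidin-2-yl carries the gain stays open, as the ring, its nitrogen and its hydroxyl enter together; an unsubstituted pyrrolidin-2-yl or an open-chain amine would separate them. Going by these compounds alone, whether the two ring stereocentres matter also remains unknown, the only comparison of configuration here concerning another arm: the fact that compounds 1 and 2 differ only in the configuration as drawn.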